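The compounds below may be only part of what the source reports. "The series", "measured", "known", "first", "only" and "open" are said of these compounds alone.

Measured so far:
Compound 1, `CN1CCC[C@H]1COc1cccnc1` — in an assay on a protein complex for binding affinity to Neuronal acetylcholine receptor; alpha3/beta2 (Homo sapiens) (on this read-out lower numbers stand for stronger inhibition and higher numbers for weaker inhibition), compound 1 gives 7.7 nM.
Compound 2, `CCCCC#Cc1cncc(OC[C@@H]2CCCN2C)c1` — in this assay compound 2 gives 21 nM.

For the measured compounds named here, compound 2 holds the higher of the two numbers, so it binds less tightly than compound 1; the single step that separates the pair, a 2.7-fold higher number from compound 1 to compound 2 (0.44 log units; beyond the scatter), is modest but lies beyond the scatter. Compound 3, `CN1CCC[C@H]1COc1cncc(C#CCCCCO)c1`, keeps everything in compound 2 and alters one spot: hydroxy in place of hydrogen on a saturated chain carbon, four bonds along the chain from a triple-bonded carbon. Going by the values given here, no measured pair shows what such a hydroxy does here; the only step available, which adds the whole chain rather than touching its tip, offers no direct guide to this change. With nothing pointing clearly in either direction, the expected step is a 1.2-fold higher number from compound 2 to compound 3 (0.08 log units; within the scatter), a shift that would stay within the usual scatter, so compound 3 should sit close to its parent. Compound 3 is therefore estimated at 25 nM in this assay, with the likely range running from 8 nM to 80 nM.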

Compound 3, inhibition constant: 13 nM
For compound 3 the middle estimate is 1.9-fold (0.28 log units) above the measured one; measured number inside the range.
By their numbers in this assay, from the lowest: compounds 1, 3 and 2 (each within the scatter of the next, the first and the last beyond it).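

Placing hydroxy on a saturated chain carbon, four bonds along the chain from a triple-bonded carbon, gives a step that stays within the scatter in this assay: a 1.6-fold lower number from compound 2 to compound 3 (0.21 log units; within the scatter). So this spot accepts the hydroxy without a clear loss or gain in binding, and the data give no firm sign that the group helps. The full 6-hydroxyhex-1-yn-1-yl group also stays within the scatter of the unsubstituted parent, at a 1.7-fold higher number from compound 1 to compound 3 (0.23 log units; within the scatter), whereas the hex-1-yn-1-yl step, a 2.7-fold higher number from compound 1 to compound 2 (0.44 log units; beyond the scatter), lies beyond it; no measurement here explains this difference.

The compounds shown leave open whether this tolerance is specific to hydroxy or would extend to other groups at the same spot, such as an amine, a carboxylic acid or a methoxy. They also leave open whether a longer chain carrying the same hydroxy would stay as close to compound 1, and whether the pattern would hold on other receptor subtypes.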